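The compounds below may be only part of what the source reports. "The series", "measured", "known", "first", "only" and "open" are said of these compounds alone.

Compound 1 `COc1ccc2c(=O)c(/C=C/C(=O)NCc3ccccc3)coc2c1` is the starting point of this comparison. In a functional assay on L02 cells (Homo sapiens) for inhibition, read by MTT assay, with a stated time of 48 h (on this read-out higher numbers stand for weaker inhibition and lower numbers for stronger inhibition), compound 1 gives only a limit of the assay, > 200000 nM, and no number. Compound 2 `COc1ccc2c(=O)c(/C=C/C(=O)Nc3ccccc3Cl)coc2c1` likewise returns only a limit in this assay, > 200000 nM. Compound 3 `COc1ccc(CNC(=O)/C=C/c2coc3cc(OC)ccc3c2=O)cc1` also gives a limit in this assay, > 200000 nM. The steps a step that the two limits leave unreadable from compound 1 to compound 2, a step that the two limits leave unreadable from compound 1 to compound 3 and a step that the two limits leave unreadable from compound 2 to compound 3 are therefore unreadable in size, because every value sits at the limit of > 200000 nM in this assay, at which 3 of the 3 values shown sit. Compound 4 `COc1ccc2c(=O)c(/C=C/C(=O)Nc3ccccc3OC)coc2c1` differs from compound 1 by 2-methoxyphenyl in place of benzyl on an amide-type nitrogen. Of the measured steps, a step that the two limits leave unreadable from compound 1 to compound 2 bears most closely on this change, yet its size cannot be read, so no direction beyond the scatter can be drawn. Compound 4 is therefore expected to remain at the limit, estimated at 300000 nM with a range of 100000 nM to 1000000 nM. The expected step is a step that the limit leaves unreadable from compound 1 to compound 4.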

Compound 4, half-maximal inhibitory concentration: > 200000 nM
Compound 4: only a limit was reported; the forecaster's own chance of this, stated with the estimate: 85%; the middle value lies beyond the limit too.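

The steps from compound 4 to compound 1, compound 2 and compound 3 cannot be read, because all four compounds sit at one limit: the limit of > 200000 nM in this assay, at which 4 of the 4 values shown sit. The compounds shown leave open whether changing the group on the amide-type nitrogen alters inhibition in this assay.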